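Replacing a Methyl with a Bromine on the Pendant Ring

A few compounds are considered here, and "the series" means these few. Any claim that something is new, unique, unknown or untested is made for them only; others in the source may bear on it.

Three compounds share one core and differ only in the ring attached through the sulfur. Compound 1 `O=C(O)Cn1c(SCc2ccccc2Cl)nc2ccccc21` gives 370 nM in an assay on HEK293 cells for displacement of a labelled ligand from prostaglandin D2 receptor 2 (Homo sapiens); a higher number here means a weaker inhibitor, a lower number a stronger inhibitor; compound 2 `COc1ccc(CSc2nc3ccccc3n2CC(=O)O)cc1` gives 210 nM; compound 3 `Cc1ccccc1CSc1nc2ccccc2n1CC(=O)O` gives 810 nM, the highest of the three numbers and so the weakest inhibitor of this set. Going by the values given here, the one measured step, a 2.2-fold higher number from compound 1 to compound 3 (0.34 log units; beyond the scatter), shows that a small change on that ring moves the number by a modest amount. Compound 4 `O=C(O)Cn1c(SCc2ccc(Br)cc2)nc2ccccc21` has not yet been measured; it carries 4-bromophenyl in place of 2-methylphenyl on a saturated chain carbon bound to a sulfur. Among the compounds with values here, no measured step involves a bromine, so the only guidance is that compound 1 and compound 2 both sit lower than compound 3. Compound 4 is therefore expected to give a lower number, a step of a 2.5-fold lower number from compound 3 to compound 4 (0.40 log units; beyond the scatter), estimated at 320 nM with a range from 120 nM to 850 nM.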

Compound 4, half-maximal inhibitory concentration: 220 nM
Compound 4: middle estimate off by 1.5-fold (0.16 log units), on the high side; low and high end bracket the measured number.
By their numbers in this assay, from the lowest: compounds 2, 4 and 1 (each within the scatter of the next); then compound 3.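

Going from 2-methylphenyl to 4-bromophenyl gives a 3.7-fold lower number from compound 3 to compound 4 (0.57 log units; beyond the scatter) and shows that bromine is accepted on this ring, while compound 3 remains apart from the other three. Bromo in place of methoxy gives a 1.0-fold higher number from compound 2 to compound 4 (0.02 log units; within the scatter) and 4-bromophenyl in place of 2-chlorophenyl gives a 1.7-fold lower number from compound 1 to compound 4 (0.23 log units; within the scatter) so neither step separates its pair. No supporting measurement explains these numbers.

Since the substituent and its place changed together, 4-methylphenyl and 2-bromophenyl would be needed to separate the two. Going by these compounds, how an amine or a carboxylic acid on this ring would behave also stays open.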